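Fluoro in place of hydrogen on the benzyl ring

The source may report more compounds than this note shows. Statements on the series, on what has been measured and on what is new or still open speak of the compounds shown alone.

Measured so far, in an ADME assay on HOS cells (Homo sapiens) for cytotoxicity; on this read-out lower numbers stand for stronger inhibition and higher numbers for weaker inhibition:
Compound 1, `O=C1c2c(ccc(O)c2O)CN1Cc1cccc(Cl)c1`, gives 9020 nM.
Compound 2, `O=C1c2ccc(O)c(O)c2C(=O)N1Cc1ccc(F)c(Cl)c1`, gives 9540 nM.
Compound 3, `O=C1c2c(ccc(O)c2O)CN1Cc1cccc(Cl)c1F`, gives 9430 nM.

The three numbers lie close together, and no order among them is claimed. Compound 3 differs from compound 1 by fluoro in place of hydrogen on an aromatic carbon; the step is a 1.0-fold higher number from compound 1 to compound 3 (0.02 log units; within the scatter). The difference between the core of compound 1 and the core of compound 2 is not broken down here.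

Compound 4, `O=C1c2ccc(O)c(O)c2C(=O)N1Cc1cc(Cl)c(F)cc1F`, is not yet measured. It differs from compound 2 by fluoro in place of hydrogen on an aromatic carbon. This is the same kind of change as from compound 1 to compound 3, not the same: there the entering fluoro sat ortho to a chloro group and ortho to a large group, here it sits ortho to a large group, meta to a fluoro group and para to a chloro group. Since the earlier step was a 1.0-fold higher number from compound 1 to compound 3 (0.02 log units; within the scatter), the step from compound 2 to compound 4 is expected to be a 1.0-fold lower number from compound 2 to compound 4 (0.00 log units; within the scatter), with the estimate resting on compound 2 at 9540 nM. For compound 4 the expected value in this assay is 9500 nM, estimated between 5000 nM and 18000 nM.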

Compound 4, half-maximal inhibitory concentration: 13700 nM
Compound 4: middle estimate off by 1.4-fold (0.16 log units), on the low side; the measured number falls inside the stated range.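

In this assay the new step is a 1.4-fold higher number from compound 2 to compound 4 (0.16 log units; within the scatter). Set beside the earlier step, fluoro in place of hydrogen on an aromatic carbon shows no difference between the two cores that can be told from the scatter: the same change on two cores in this assay, a 1.0-fold higher number (0.02 log units; within the scatter) from compound 1 to compound 3 and a 1.4-fold higher number (0.16 log units; within the scatter) from compound 2 to compound 4, 1.4-fold (0.14 log units) apart, within the scatter of two such steps

This does not show that the change is without effect on every core: the entering fluoro stands at a different place in each pair, and two pairs set no rule for other cores or places.

The compounds shown carry only chloro and fluoro groups on the benzyl ring. As far as these compounds go, what an amine, a carboxylic acid or a longer chain on that ring would give in this assay remains open.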